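Aryl amide variation on the shared core

The compounds below may be only part of what the source reports. "The series", "measured", "known", "first", "only" and "open" are said of these compounds alone.

Of the compounds shown here, three on the shared core have been measured in an assay (strain Wistar) for displacement of a labelled ligand from adenosine receptor A1 (Rattus norvegicus), read by scintillation counting; a higher number here means a weaker inhibitor, a lower number a stronger inhibitor. Compound 1 `O=C(Nc1nc(-c2ccccc2)nc2c1nnn2Cc1ccccc1)C1CCCCC1` gives 12 nM. Compound 2 `COc1ccc(Cl)cc1C(=O)Nc1nc(-c2ccccc2)nc2c1nnn2Cc1ccccc1` gives 7150 nM, and compound 3 `COc1ccccc1C(=O)Nc1nc(-c2ccccc2)nc2c1nnn2Cc1ccccc1` gives 1520 nM. Compound 3 thus stands second highest of the three numbers: a 130-fold higher number from compound 1 to compound 3 (2.10 log units; beyond the scatter) separates it from compound 1, and a 4.7-fold lower number from compound 2 to compound 3 (0.67 log units; beyond the scatter) from compound 2. Both aryl amides lie far above the cyclohexyl amide, as a 600-fold higher number from compound 1 to compound 2 (2.78 log units; beyond the scatter) also shows.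

Compound 4 `Cc1ccc(C(=O)Nc2nc(-c3ccccc3)nc3c2nnn3Cc2ccccc2)cc1` is the next step from compound 3: 4-methylphenyl in place of 2-methoxyphenyl on a carbonyl carbon. For the measured compounds named here, no measured step removes a methoxy group or introduces a methyl group, so the bearing of the earlier steps is indirect. The step of a 4.7-fold lower number from compound 2 to compound 3 (0.67 log units; beyond the scatter) shows that a substituent change on an aryl amide moves this assay by a modest amount, whereas the aryl-for-cyclohexyl steps were large. Compound 4 keeps an aryl amide, so no large shift is expected; a modest move in either direction is plausible, and the expected step is a 1.9-fold lower number from compound 3 to compound 4 (0.28 log units; within the scatter). Compound 4 is therefore estimated at 800 nM, with an expected range of 150 nM to 4000 nM.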

Compound 4, inhibition constant: 709 nM
For compound 4 the middle estimate is 1.1-fold (0.05 log units) above the measured one; the range from low to high includes it.
By their numbers in this assay, from the lowest: compound 1; then compound 4; then compound 3; then compound 2.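

In this assay, 4-methylphenyl in place of 2-methoxyphenyl on a carbonyl carbon gives a 2.1-fold lower number from compound 3 to compound 4 (0.33 log units; beyond the scatter) as a modest step, and the same aryl amide position also gives a 10-fold lower number from compound 2 to compound 4 (1.00 log units; beyond the scatter) against the 5-chloro-2-methoxyphenyl amide, so compound 4, which has no methoxy group, has the lowest number of the three aryl amides. Even so, a 59-fold higher number from compound 1 to compound 4 (1.77 log units; beyond the scatter) keeps it well above the cyclohexyl amide, so the large gap between cyclohexyl and aryl persists without the methoxy group, though it is narrower than for compound 2 and compound 3. Nothing measured here accounts for these steps.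

The step from compound 3 to compound 4 changes both the substituent and its place on the ring, so the two contributions cannot be separated. Unsubstituted phenyl, 2-methylphenyl and 4-methoxyphenyl would separate them, while cyclopentyl or a longer alkyl chain would test how far the low number of compound 1 extends among non-aromatic amides.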